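Amide nitrogen series: hexylamino to diisobutylamino

This account rests on a few compounds, and the source may have more. Where it says the series, first, only, none or still open, it means among the compounds named here.

In a functional assay on B16-F10 cells (Mus musculus) for inhibition, read by MTT assay, with a stated time of 48 h (on this read-out higher numbers stand for weaker inhibition and lower numbers for stronger inhibition), compound 1 `CCC(C)NC(=O)/C=C/c1c(/C=C/c2ccc(OC)cc2)cc(OC)cc1OC` gives 4380 nM and compound 2 `CCCCCCNC(=O)/C=C/c1c(/C=C/c2ccc(OC)cc2)cc(OC)cc1OC` gives 7180 nM. These two values lie within the scatter of each other, so the numbers set compound 2 apart from compound 1 in neither direction.

Compound 3 `COc1ccc(/C=C/c2cc(OC)cc(OC)c2/C=C/C(=O)N(CC(C)C)CC(C)C)cc1` keeps the shared core and differs from compound 2 at the amide end: diisobutylamino in place of hexylamino on a carbonyl carbon. In words, diisobutylamino stands in place of hexylamino on a carbonyl carbon, and the amide hydrogen is lost.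

For the measured compounds named here, only one measured step bears on this change: a 1.6-fold higher number from compound 1 to compound 2 (0.21 log units; within the scatter). It swaps one chain on the amide-type nitrogen for another, and the size of that step gives no sign that the chain matters in this assay. Going by the values given here, that step keeps the amide hydrogen, however, and no measured compound lacks it, so this part of the change is untested and the range has to stay wide.

The expected step is a 1.2-fold lower number from compound 2 to compound 3 (0.08 log units; within the scatter), which is not expected to exceed the scatter. For compound 3 the estimate is 6000 nM, with an expected range of 2200 nM to 16000 nM.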

Compound 3, half-maximal inhibitory concentration: 4850 nM
Estimate against measurement, compound 3: 1.2-fold (0.09 log units) above; the range from low to high includes it.
By their numbers in this assay, from the lowest: compounds 1, 3 and 2 (each within the scatter of the next).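

Notes on the amide end: in this assay the loss of the amide hydrogen, untested until now, has its first reading, and it comes with a change of chain. Going from hexylamino to diisobutylamino gives (a 1.5-fold lower number from compound 2 to compound 3 (0.17 log units; within the scatter)), and going from (sec-butyl)amino to diisobutylamino gives (a 1.1-fold higher number from compound 1 to compound 3 (0.04 log units; within the scatter)). Neither step leaves the scatter, so in these three compounds neither the form of the chain on the nitrogen nor the absence of the amide hydrogen sets any compound apart, although each step carries both changes together and cannot divide them. Nothing measured alongside these values offers an explanation of this result.

For the compounds shown here, all the groups at this position so far are plain saturated carbon chains on the amide nitrogen, so it remains open whether a terminal amine, a carboxylic acid or a morpholine ring there would move the number beyond the scatter. As far as these compounds go, a single methyl group added to the nitrogen of the hexylamino amide would remove the amide hydrogen while keeping the hexyl chain, and its effect on its own remains open.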